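Adding Fluoro to the Strongest Inhibitor of Three

The source may report more compounds than this note shows. Statements on the series, on what has been measured and on what is new or still open speak of the compounds shown alone.

Of the compounds shown here, three sharing one core have been measured in a functional assay on MDA-MB-231 cells (Homo sapiens) for inhibition, read by MTT assay, with a stated time of 72 h; a higher number here means a weaker inhibitor, a lower number a stronger inhibitor. Compound 3 `COc1ccccc1-c1csc2cnc(Nc3ccc(C(=O)NC4CCNCC4)cc3)nc12` gives 110 nM, the lowest number of the three. Compound 4 `COc1ccccc1-c1csc2cnc(Nc3ccc(C(=O)NC4CCNCC4)cc3F)nc12` differs from compound 3 in one place: fluoro in place of hydrogen on an aromatic carbon.

Compound 2 `COc1ccccc1-c1csc2cnc(Nc3ccc(C(=O)NC4CCNCC4)cc3C(F)(F)F)nc12` carries trifluoromethyl on that same carbon and gives 2750 nM. Going by the values given here, the one measured step bearing on this change is large: a 25-fold lower number from compound 2 to compound 3 (1.40 log units; beyond the scatter). Compound 1 `COc1ccccc1-c1csc2cnc(Nc3cc(F)c(C(=O)NC4CCNCC4)cc3F)nc12` has fluoro on that carbon, with further fluoro on the same ring, and gives 2570 nM. Neither compound shows the effect of this single fluoro alone, so the size of the step remains uncertain.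

A higher number is expected, but with a smaller gap than those seen so far, an estimated step of a 3.6-fold higher number from compound 3 to compound 4 (0.56 log units; beyond the scatter). Compound 4 is estimated at 400 nM, with an expected range from 130 nM to 1500 nM.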

Compound 4, half-maximal inhibitory concentration: 1610 nM
Compound 4: the middle estimate sits 4.0-fold (0.60 log units) below what was measured, outside the stated range (above it).
By their numbers in this assay, from the lowest: compound 3; then compounds 4, 1 and 2 (each within the scatter of the next).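

The single fluoro shows that even the smallest change tried at this carbon carries nearly the whole loss: in this assay the step is a 15-fold higher number from compound 3 to compound 4 (1.17 log units; beyond the scatter). Fluoro and trifluoromethyl cannot be told apart here, with a 1.7-fold lower number from compound 2 to compound 4 (0.23 log units; within the scatter), and the further fluoro on the same ring adds no separable effect, with a 1.6-fold lower number from compound 1 to compound 4 (0.20 log units; within the scatter). Among these compounds, then, hydrogen on this carbon goes with the low number, and each of the three compounds carrying a fluorinated group there sits far higher, but nothing available explains this.

Still open, as far as these compounds go, is whether the loss holds for every group on this carbon, which a hydroxyl, a methoxy or an amine there would test. It is also unknown whether the further fluoro of compound 1 would matter alone, with hydrogen on this carbon.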